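Carbamate series: fluoro to cyano on the outer ring

The compounds below may be only part of what the source reports. "The series", "measured", "known", "first", "only" and "open" are said of these compounds alone.

Measured so far:
compound 1, `O=C(NC1CCCCC1)Oc1cccc(-c2cccc(F)c2)c1`, an assay on cell membranes for binding affinity to Fatty-acid amide hydrolase 1 (Rattus norvegicus) (a higher number here means a weaker inhibitor, a lower number a stronger inhibitor), 96.6 nM
compound 2, `CC(=O)c1cccc(-c2cccc(OC(=O)NC3CCCCC3)c2)c1`, this assay 9.1 nM

Compound 1 stands highest of the two numbers in this assay; compound 2 is its nearest neighbour and the only other point. For the measured compounds named here, the single measured step, an 11-fold lower number from compound 1 to compound 2 (1.03 log units; beyond the scatter), went with acetyl in place of fluoro on an aromatic carbon, a swap at the same place on the outer ring of the shared core.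

Compound 3, `N#Cc1cccc(-c2cccc(OC(=O)NC3CCCCC3)c2)c1`, is not yet measured. It differs from compound 1 by cyano in place of fluoro on an aromatic carbon. The acetyl step is the only one that bears on this change: both replace fluoro at the same aromatic carbon, and both bring in a group that adds one hydrogen-bond acceptor where fluoro had none. That step was large and downward. With nothing else to go on, a step in the same direction is expected, but no measured point supports a size as large as the acetyl one. The expected step is a 4.8-fold lower number from compound 1 to compound 3 (0.68 log units; beyond the scatter). Compound 3 is therefore estimated at 20 nM, with a range from 6 nM to 70 nM.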

Compound 3, half-maximal inhibitory concentration: 33.9 nM
Estimate against measurement, compound 3: 1.7-fold (0.23 log units) below; low and high end bracket the measured number.
By their numbers in this assay, from the lowest: compound 2; then compound 3; then compound 1.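

In this assay, cyano is a second replacement for fluoro at this aromatic carbon that goes with a lower number, a 2.8-fold lower number from compound 1 to compound 3 (0.45 log units; beyond the scatter), so the downward direction no longer rests on acetyl alone. The two replacements do not go equally far, however: a 3.7-fold higher number from compound 2 to compound 3 (0.57 log units; beyond the scatter), which means that the size of the change depends on which group enters, and that a hydrogen-bond acceptor present in both entering groups does not settle it. For the compounds shown here, with only three compounds, the order acetyl, then cyano, then fluoro is a description of these points alone, and no supporting measurement is available to explain it.

The compounds shown leave open whether other groups at this carbon, such as an amine, a carboxylic acid, a methyl ester or a longer chain, would extend this order or break it. They also leave open whether the steps from fluoro to cyano and to acetyl would keep their direction and size if the cyclohexyl group on the carbamate were replaced by another group, such as a longer alkyl chain.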